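A few compounds are considered here, and "the series" means these few. Any claim that something is new, unique, unknown or untested is made for them only; others in the source may bear on it.

In a functional assay on NCI-H460 cells (Homo sapiens) for antiproliferative activity, read by MTT assay, with a stated time of 48 h (on this read-out higher numbers stand for weaker inhibition and lower numbers for stronger inhibition), compound 3 `COc1cc(-c2cccc3nc(-c4cccc(Cl)c4)oc23)cc(OC)c1OC` gives > 25000 nM, which is a limit and not a number. Compound 1 `COc1ccc(-c2nc3cccc(-c4cc(OC)c(OC)c(OC)c4)c3o2)cc1F` gives 2800 nM and compound 2 `COc1cc(-c2cccc3nc(-c4cccc(Br)c4)oc23)cc(OC)c1OC` gives 3800 nM. These two values belong together, as a 1.4-fold higher number from compound 1 to compound 2 (0.13 log units; within the scatter) shows.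

The next change leads to compound 4 `COc1cc(-c2cccc3nc(-c4cccc(O)c4)oc23)cc(OC)c1OC`: hydroxy in place of chloro on an aromatic carbon. In words, this is hydroxy in place of chloro on an aromatic carbon, meta to a large group, or 3-chlorophenyl to 3-hydroxyphenyl.

Within the data shown here, two measured steps bear on it most directly. One is an at least 6.5-fold higher number from compound 2 to compound 3 (0.81 log units; beyond the scatter), a swap of one substituent for another on this aryl group. The other is an at least 8.9-fold higher number from compound 1 to compound 3 (0.95 log units; beyond the scatter). Both end at a limit, so their sizes are bounds only. They show that changes to this aryl group can move the number by more than the scatter, but neither tests a hydroxy group.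

Compound 3 offers no number to start from, so staying at the limit remains plausible. A return toward the level of compound 2 at 3800 nM is also possible. A modest move toward stronger inhibition is expected, and the expected step is an at least 2.7-fold lower number from compound 3 to compound 4 (0.44 log units; beyond the scatter). Compound 4 is estimated at 9000 nM, with an expected range of 2000 nM to 25000 nM.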

Compound 4, half-maximal inhibitory concentration: 1900 nM
For compound 4 the middle estimate is 4.7-fold (0.68 log units) above the measured one, outside the stated range (below it).
By their numbers in this assay, from the lowest: compounds 4, 1 and 2 (each within the scatter of the next). At a limit, above all of these: compound 3.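

In this assay compound 3 gives > 25000 nM, which is a limit and not a number, so the size of any step from it is a bound only: the limit of > 25000 nM in this assay, at which 1 of the 4 values shown sits.

Hydroxy in place of chloro on this aromatic carbon, meta to a large group, gives an at least 13-fold lower number from compound 3 to compound 4 (1.11 log units; beyond the scatter), so the loss seen with compound 3 does not extend to every small substituent at this place. The other two steps, a 2.0-fold lower number from compound 2 to compound 4 (0.30 log units; within the scatter) and a 1.5-fold lower number from compound 1 to compound 4 (0.17 log units; within the scatter), both lie within the scatter, which puts the 3-hydroxyphenyl, 3-bromophenyl and 3-fluoro-4-methoxyphenyl compounds at one level, with compound 3 alone standing apart from them.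

The compounds shown do not tell why chloro departs from both bromo and hydroxy at this place, and a single compound at a limit is thin ground for any rule about this position. Going by these compounds, whether an amine, a carboxylic acid or a methoxy group on this same carbon would stay at the level of compound 4 remains open.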